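From compound 1 to compound 3: a ring change

A few compounds are considered here, and "the series" means these few. Any claim that something is new, unique, unknown or untested is made for them only; others in the source may bear on it.

In an ADME assay on microsomes from liver (Homo sapiens) for metabolic stability (on this read-out lower numbers stand for slow clearance and higher numbers for fast clearance), compound 1 (`CC(=O)N[C@@H]1CCC[C@H](C(=O)Nc2cc(-c3cnn4c3CCCCC4)c(Cl)cn2)C1`) gives 39 mL.min-1.g-1, the lowest of the two numbers at hand. Among the measured compounds shown here, compound 2 (`CC(=O)N[C@@H]1CCC[C@H](C(=O)Nc2cc(-c3cnn4c3CC(C)(C)CC4)c(F)cn2)C1`) gives 178 mL.min-1.g-1, a gap beyond the scatter, but the two compounds differ in more than one place and so offer no clean step. Compound 3 (`CC(=O)N[C@@H]1CCC[C@H](C(=O)Nc2cc(-c3cnn4c3CC(C)(C)C4)c(Cl)cn2)C1`) has the same atoms as compound 1, joined differently: a group of 10 heavy atoms (8 carbon, 2 nitrogen; one five-membered non-aromatic ring with 1 hetero atom, one five-membered aromatic ring with 2 hetero atoms) in place of a group of 10 heavy atoms (8 carbon, 2 nitrogen; one five-membered aromatic ring with 2 hetero atoms, one seven-membered non-aromatic ring with 1 hetero atom), on an aromatic carbon. A group with a five-membered non-aromatic ring with 1 hetero atom replaces one with a seven-membered non-aromatic ring with 1 hetero atom, on an aromatic carbon ortho to a chloro group. For the measured compounds named here, no measured pair isolates this change, so no shift beyond the scatter is expected in this assay. The expected change is a 1.2-fold higher number from compound 1 to compound 3 (0.06 log units; within the scatter). Compound 3 is estimated at 45 mL.min-1.g-1, with an expected range of 18 mL.min-1.g-1 to 120 mL.min-1.g-1.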

Compound 3, intrinsic clearance in microsomes: 50 mL.min-1.g-1
Compound 3: the middle estimate sits 1.1-fold (0.05 log units) below what was measured; low and high end bracket the measured number.
By their numbers in this assay, from the lowest: compounds 1 and 3 (each within the scatter of the next); then compound 2.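

In this assay the series gets its first clean step, which reads a 1.3-fold higher number from compound 1 to compound 3 (0.11 log units; within the scatter) and puts the seven-membered and five-membered non-aromatic rings level at this place, on an aromatic carbon ortho to a chloro group. With the same atoms joined differently, this one pair shows no shift in ring size that can be told from the scatter, though a single pair sets no rule for other groups here. No measurement at hand explains why the two rings read alike.

Compound 2 differs from compound 1 in more than one place, so its higher number cannot yet be assigned to any single change. Also open, on these data alone, is how a hydroxyl group or a ring oxygen in the non-aromatic ring would read in this assay at this place.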